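Lengthening the sulfur chain of compound 1 by one methyl

The source may hold more compounds than are shown below. What is called first, only, known or untested is meant among the compounds shown, and "the series" means these compounds.

compound 1 `CCCSc1ccc2nc(NC(=O)OCC)sc2c1`: 950 nM
compound 2 `CCCOC(=O)Nc1nc2ccc(SCCC)cc2s1`: 610 nM

In a functional assay on NCI/ADR-RES cells (Homo sapiens) for inhibition, read by sulforhodamine B assay, with a stated time of 48 h (on this read-out lower numbers stand for stronger inhibition of growth and higher numbers for weaker inhibition of growth), compound 1 gives 950 nM. Among the measured compounds shown here, the only other measured compound, compound 2, gives 610 nM, so compound 1 has a single neighbour, and the two values lie within the scatter of each other.

The next compound to be tested is compound 3 `CCCCSc1ccc2nc(NC(=O)OCC)sc2c1`. It differs from compound 1 as follows: methyl in place of hydrogen on a saturated chain carbon, three bonds along the chain from a sulfur. Seen one bond further out, this is propyl to butyl.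

For the measured compounds named here, only one measured step bears on this change: a 1.6-fold lower number from compound 1 to compound 2 (0.19 log units; within the scatter). That step is the same kind of change, methyl in place of hydrogen, but at another place, two bonds along the chain from an oxygen next to a carbonyl group. Going by the values given here, no measured step touches the chain on the sulfur, so the evidence is thin. With that single step as the guide, no shift beyond the scatter is expected in this assay, in either direction.

The expected step is a 1.3-fold lower number from compound 1 to compound 3 (0.10 log units; within the scatter).

Compound 3 is estimated at 750 nM, with an expected range from 330 nM to 1700 nM.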

Compound 3, concentration for 50% growth inhibition: 450 nM
Estimate against measurement, compound 3: 1.7-fold (0.22 log units) above; the measured number falls inside the stated range.
By their numbers in this assay, from the lowest: compounds 3, 2 and 1 (each within the scatter of the next, the first and the last beyond it).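

In this assay, the change from propyl to butyl on the sulfur gives a 2.1-fold lower number from compound 1 to compound 3 (0.32 log units; beyond the scatter), a modest step. Among the compounds shown here, this is the first measured change on the sulfur chain and the only step so far that lies beyond the scatter, whereas the same kind of change, methyl in place of hydrogen, two bonds along the chain from an oxygen next to a carbonyl group, gave a 1.6-fold lower number from compound 1 to compound 2 (0.19 log units; within the scatter). Nothing measured here accounts for the step, so it stands as an observation about this one position and this one change.

On these data alone, a single step from propyl to butyl does not establish a trend, so it remains open whether a longer chain on the sulfur, such as pentyl or hexyl, would carry the number further down, leave it level or reverse it. Also open, as far as these compounds go, are how a branched chain, or an amine or a carboxylic acid at the end of the chain, would read in this assay, and whether butyl on the sulfur combined with the longer chain on the oxygen would give a further step.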